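A few compounds are considered here, and "the series" means these few. Any claim that something is new, unique, unknown or untested is made for them only; others in the source may bear on it.

Working notes on the series. Among the measured compounds shown here, in an ADME assay on microsomes from liver (Rattus norvegicus) for metabolic stability, with a stated time of 60 min (on this read-out higher numbers stand for a more stable compound and lower numbers for a less stable compound), compound 1 `O=C(O)c1cc(-c2cccc(COc3ccc4c(c3)CN(C3CCCCC3)C4=O)c2)ccc1Cl` gives 1%, the lowest of the three numbers so far. Compound 2 `O=C(O)c1cc(-c2cccc(COc3ccc4c(c3)CN(c3ccccc3)C4=O)c2)ccc1Cl` gives 100% in this assay, and compound 3 `CCCN1Cc2cc(OCc3cccc(-c4ccc(Cl)c(C(=O)O)c4)c3)ccc2C1=O` gives 96%. Both measured steps away from the cyclohexyl compound are large, a number 99 percentage points higher from compound 1 to compound 2 (beyond the scatter) and a number 95 percentage points higher from compound 1 to compound 3 (beyond the scatter), while between the two replacements themselves the step is small, a number 4 percentage points lower from compound 2 to compound 3 (within the scatter). Compound 4 `CC(C)CN1Cc2cc(OCc3cccc(-c4ccc(Cl)c(C(=O)O)c4)c3)ccc2C1=O` differs from compound 1 as follows: isobutyl in place of cyclohexyl on an amide-type nitrogen in a ring. The two measured steps that bear on this change, from compound 1 to compound 2 and from compound 1 to compound 3, both removed the cyclohexyl from the amide-type nitrogen in the ring and both carried the read-out close to full recovery; the propyl case is the nearer analogue of isobutyl. A large step upward in this assay is therefore expected for compound 4, a number 89 percentage points higher from compound 1 to compound 4 (beyond the scatter). The estimate for compound 4 in this assay is 90%, with an expected range from 60% to 100%.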

Compound 4, percent of the compound remaining: 43%
Compound 4: the middle estimate sits 47 percentage points above what was measured; measured number below the stated range.
By their numbers in this assay, from the lowest: compound 1; then compound 4; then compounds 3 and 2 (each within the scatter of the next).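

Taking the cyclohexyl off the amide-type nitrogen in the ring is not enough by itself to reach the top of the range in this assay: isobutyl gives a number 42 percentage points higher from compound 1 to compound 4 (beyond the scatter), but it also gives a number 57 percentage points lower from compound 2 to compound 4 (beyond the scatter) when set against phenyl. This position is sensitive to a change as small as one methyl, since methyl in place of hydrogen on a saturated chain carbon bound to two saturated chain carbons gives a number 53 percentage points lower from compound 3 to compound 4 (beyond the scatter), a step of the same order as those that separate the cyclohexyl compound from the others. Nothing available explains this sensitivity.

Open, going by these compounds, is whether a longer straight chain such as butyl stays with propyl or falls towards isobutyl. Also open, on these data alone, is how a chain carrying a hydroxyl or an amine at this nitrogen would behave.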